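This account rests on a few compounds, and the source may have more. Where it says the series, first, only, none or still open, it means among the compounds named here.

Measured so far in an assay on isolated protein for inhibition of Fatty-acid amide hydrolase 1 (Homo sapiens), read by fluorescence, with a stated time of 30 min; a lower number here means a stronger inhibitor, a higher number a weaker inhibitor:
compound 1 `CCOC(=O)c1cc(-c2cccc(OC(=O)NC3CCCCC3)c2)n(-c2ccc(OC)cc2)n1` — 103 nM
compound 2 `CCOC(=O)c1cc(-c2cccc(OC(=O)NC3CCCCC3)c2)n(-c2ccc(C)cc2)n1` — 29 nM

Within the data shown here, compound 2 stands at the lowest of the two numbers in this assay; the single step, a 3.6-fold lower number from compound 1 to compound 2 (0.55 log units; beyond the scatter), separates it from compound 1. Compound 3 `CCOC(=O)c1cc(-c2cccc(OC(=O)NC3CCCCC3)c2)n(-c2ccc(C(F)(F)F)cc2)n1` differs from compound 2 by trifluoromethyl in place of methyl on an aromatic carbon. Among the measured compounds shown here, no measured step covers this exchange; the step from compound 1 to compound 2 shows only that the group on this ring shifts the number, without telling the direction for the new entry. The expected change is small, a 1.2-fold higher number from compound 2 to compound 3 (0.08 log units; within the scatter), within the scatter. Compound 3 is estimated at 35 nM, range 10 nM to 120 nM.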

Compound 3, half-maximal inhibitory concentration: 132 nM
For compound 3 the middle estimate is 3.8-fold (0.58 log units) below the measured one; measured number outside the range, above it.
By their numbers in this assay, from the lowest: compound 2; then compounds 1 and 3 (each within the scatter of the next).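

In this assay the exchange of 4-methylphenyl for 4-(trifluoromethyl)phenyl gives a 4.6-fold higher number from compound 2 to compound 3 (0.66 log units; beyond the scatter) and is therefore not neutral at this position. Trifluoromethyl and methoxy are not told apart here, with a 1.3-fold higher number from compound 1 to compound 3 (0.11 log units; within the scatter) as the step between them, so among these three groups only methyl stands apart, with the lowest number. No available evidence bears on the origin of this difference.

On these data alone, whether a chlorine atom, an ethyl group or a longer chain at this position would stay with methyl or with the other two remains open. Also open, as far as these compounds go, is whether the same ordering holds with a carboxylic acid in place of the ethyl ester.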